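The source may hold more compounds than are shown below. What is called first, only, known or untested is meant among the compounds shown, and "the series" means these compounds.

Compound 1 `C[Se]/C(=N\C(=O)c1ccco1)NC(=O)c1ccco1` and compound 2 `CS/C(=N\C(=O)c1ccco1)NC(=O)c1ccco1` share a core and differ in one place: a group of 2 heavy atoms (1 carbon, 1 selenium; no ring) in place of a group of 2 heavy atoms (1 carbon, 1 sulfur; no ring), on a carbon with a double bond to nitrogen. In a functional assay on HepG2 cells (Homo sapiens) for cytotoxicity, read by MTT assay, with a stated time of 72 h (a higher number here means a weaker inhibitor of growth, a lower number a stronger inhibitor of growth), compound 2 gives only a limit of the assay, > 100000 nM (the limit of > 100000 nM in this assay, at which 1 of the 3 values shown sits). Compound 1 gives 8660 nM in this assay, so the change brings an at least 11-fold lower number from compound 2 to compound 1 (1.06 log units; beyond the scatter). Compound 3 `CS/C(=N\C(=O)c1cc(-c2ccccc2)nc2ccccc12)NC(=O)c1cc(-c2ccccc2)nc2ccccc12` carries a different core, and the difference between the two cores is not broken down here; in this assay compound 3 gives 48200 nM. Compound 4 `C[Se]/C(=N\C(=O)c1cc(-c2ccccc2)nc2ccccc12)NC(=O)c1cc(-c2ccccc2)nc2ccccc12` is made from compound 3 by the same change, (a group of 2 heavy atoms (1 carbon, 1 selenium; no ring) in place of a group of 2 heavy atoms (1 carbon, 1 sulfur; no ring), on a carbon with a double bond to nitrogen). Because the earlier step of an at least 11-fold lower number from compound 2 to compound 1 (1.06 log units; beyond the scatter) was large, the step from compound 3 to compound 4 is expected to be large as well, about an 8.0-fold lower number from compound 3 to compound 4 (0.90 log units; beyond the scatter). Compound 4 is therefore estimated at 6000 nM, expected between 2000 nM and 25000 nM.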

Compound 4, concentration for total growth inhibition: 10100 nM
Estimate against measurement, compound 4: 1.7-fold (0.23 log units) below; the range from low to high includes it.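

In this assay, putting the selenium group in place of methylsulfanyl on the second core gives a 4.8-fold lower number from compound 3 to compound 4 (0.68 log units; beyond the scatter), and the change lowers the number on both cores shown: the same change on two cores in this assay, an at least 11-fold lower number (1.06 log units; beyond the scatter) from compound 2 to compound 1 and a 4.8-fold lower number (0.68 log units; beyond the scatter) from compound 3 to compound 4; the limit leaves it open whether they differ. The value of compound 2, > 100000 nM, is a limit of the assay and not a number. The direction of the change therefore carried over between these two cores, but the data do not show whether its size did, and two cores do not make a rule for the series.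

The compounds shown leave open whether a longer chain on the selenium would give a similar result. They also leave open whether the change would go the same way on a core bearing an amine or a carboxylic acid.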